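Removing one methoxy from compound 2

The source may report more compounds than this note shows. Statements on the series, on what has been measured and on what is new or still open speak of the compounds shown alone.

Two members of the series have been measured in a functional assay on SNB-19 cells (Homo sapiens) for inhibition, read by sulforhodamine B assay, with a stated time of 48 h; on this read-out lower numbers stand for stronger inhibition of growth and higher numbers for weaker inhibition of growth. Compound 1 `Nc1cc(N)c2nc(-c3ccccc3)c(NCc3ccc(Cl)c(Cl)c3)nc2c1` gives 22400 nM and compound 2 `COc1cc(CNc2nc3cc(N)cc(N)c3nc2-c2ccccc2)cc(OC)c1OC` gives 7240 nM. Compound 2 thus stands at the lower of the two numbers, and since its gap to compound 1 is beyond the scatter, compound 2 is the stronger of the pair. Whether that gap rests on the methoxy groups or on the chlorine substituents cannot be told, as the two compounds differ in more than one place.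

Compound 3 `COc1ccc(CNc2nc3cc(N)cc(N)c3nc2-c2ccccc2)cc1OC` differs from compound 2 in a single change: hydrogen in place of methoxy on an aromatic carbon. Among the compounds with values here, no step between two measured compounds matches this change, so there is nothing to set its size against. The expected step from compound 2 to compound 3 in this assay is a small shift toward a higher number, possibly none beyond the scatter, a 1.3-fold higher number from compound 2 to compound 3 (0.12 log units; within the scatter). Compound 3 is therefore estimated at 9500 nM, within a range of 3000 nM to 30000 nM.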

Compound 3, concentration for 50% growth inhibition: 25700 nM
The estimate for compound 3 lay 2.7-fold (0.43 log units) below the measured number; low and high end bracket the measured number.
By their numbers in this assay, from the lowest: compound 2; then compounds 1 and 3 (each within the scatter of the next).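

In this assay the methoxy on this aromatic carbon, ortho to a methoxy group and meta to a large group, proves to matter: hydrogen in its place gives a 3.5-fold higher number from compound 2 to compound 3 (0.55 log units; beyond the scatter), a modest step beyond the scatter towards weaker inhibition of growth. The pair that could not be read before now has a one-place comparison, since 3,4-dimethoxyphenyl in place of 3,4-dichlorophenyl on the saturated chain carbon gives a 1.1-fold higher number from compound 1 to compound 3 (0.06 log units; within the scatter), within the scatter, so these two aryl groups are not told apart here. Within the data shown here, of the single changes read so far, only the one at this methoxy position moves the number beyond the scatter. No measurement at hand bears on the cause of this step.

Going by these compounds, whether methoxy itself is needed at this position remains open, as the comparison covers only methoxy and hydrogen, and a hydroxyl, a fluorine, an ethoxy or an amine on the same carbon could separate these possibilities. Also open, on these data alone, is whether the step keeps its size when the phenyl on the shared core is replaced, for example by a pyridine.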